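Cytotoxicity notes on a diarylamine triene series

The source may report more compounds than this note shows. Statements on the series, on what has been measured and on what is new or still open speak of the compounds shown alone.

Compound 1 `C=C[C@@](C)(/C=C/c1ccc(Nc2cccc(OC(F)(F)F)c2)cc1)CCC=C(C)C`, compound 2 `C=C[C@@](C)(/C=C/c1ccc(Nc2ccc(OC(F)(F)F)cc2)cc1)CCC=C(C)C` and compound 3 `C=C[C@@](C)(/C=C/c1ccc(Nc2ccc(C(F)(F)F)cc2)cc1)CCC=C(C)C` have been run in an ADME assay on HEK293 cells (Homo sapiens) for cytotoxicity, with a stated time of 72 h (on this read-out lower numbers stand for an effect already at smaller amounts and higher numbers for an effect only at larger amounts of compound), while compound 4 `C=C[C@@](C)(/C=C/c1ccc(Nc2cccc(C(F)(F)F)c2)cc1)CCC=C(C)C` has not. In this assay compound 1 gives > 36600 nM, which is a limit of the assay and not a number. In this assay compound 2 gives > 36600 nM, likewise a limit. In this assay compound 3 gives > 36600 nM, again a limit. The change from compound 2 to compound 3, (trifluoromethyl in place of trifluoromethoxy on an aromatic carbon), yields a step that the two limits leave unreadable from compound 2 to compound 3; the step cannot be sized because of the limit of > 36600 nM in this assay, at which 3 of the 3 values shown sit. The cores of compound 1 and compound 2 hold the same atoms joined differently, and the difference between the two cores is not broken down here. Compound 4 arises from compound 1 by trifluoromethyl in place of trifluoromethoxy on an aromatic carbon. This is the same kind of change as that from compound 2 to compound 3, not the same one: in compound 1 the place is meta to a large group, whereas in compound 2 it is para to a large group. For compound 4 in this assay the expected outcome is a value at the limit as well. The expected step, a step that the limit leaves unreadable from compound 1 to compound 4, stands beside the measured step that the two limits leave unreadable from compound 2 to compound 3 and rests on (the limit of > 36600 nM in this assay, at which 3 of the 3 values shown sit). The estimate for compound 4 in this assay is 50000 nM, expected between 30000 nM and 150000 nM.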

Compound 4, half-maximal effective concentration: > 36600 nM
Compound 4 gave a limit, no number; the forecaster's own chance of this, stated with the estimate: 85%; the middle value lies beyond the limit too.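

No new step can be read: the step from compound 1 to compound 4 cannot be sized, because both compounds stand at a limit of the assay and not at a number in this assay: the limit of > 36600 nM in this assay, at which 4 of the 4 values shown sit. From the compounds shown here alone, what stays open is how far compound 1, compound 2, compound 3 and compound 4 lie from that limit in this assay and whether trifluoromethyl and trifluoromethoxy differ there at all.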